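The source may report more compounds than this note shows. Statements on the series, on what has been measured and on what is new or still open speak of the compounds shown alone.

Measured compounds:
Compound 1 `Nc1ccccc1NC(=O)c1ccc(CSC(=S)N2CCN(c3cccnc3)CC2)cc1` gives 72.5% in a functional assay on HeLa cells (Homo sapiens) for antiproliferative activity, read by CCK-8 assay, with a stated time of 72 h, tested at 8 uM; on this read-out higher numbers stand for a stronger effect at the one concentration tested and lower numbers for a weaker effect.
Compound 2 `Nc1ccccc1NC(=O)c1ccc(CSC(=S)N2CCN(Cc3ccncc3)CC2)cc1` gives 72.9% in this assay.
Compound 3 `Nc1ccccc1NC(=O)c1ccc(CSC(=S)N2CCN(Cc3cccnc3)CC2)cc1` gives 78% in this assay.

On these three numbers compound 3 gives the highest value, but its steps to both neighbours are within the scatter: a number 5.5 percentage points higher from compound 1 to compound 3 (within the scatter) and a number 5.1 percentage points higher from compound 2 to compound 3 (within the scatter). The third measured step, a number 0.4 percentage points higher from compound 1 to compound 2 (within the scatter), is within the scatter too. So far, then, every change at the amine nitrogen in the ring has left the read-out essentially where it was.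

Compound 4 `Nc1ccccc1NC(=O)c1ccc(CSC(=S)N2CCN(Cc3ccccc3)CC2)cc1` has not yet been measured in this assay. It differs from compound 3 in one place: phenyl in place of pyridin-3-yl on a saturated chain carbon bound to an amine nitrogen in a ring. For the measured compounds named here, none of the measured steps removes the ring nitrogen; they only move it or insert a saturated chain carbon, and all were within the scatter. Going by the values given here, there is therefore no measured step that points to a change beyond the scatter here. For compound 4 the expectation is a value close to its parent, with an expected step of a number 4 percentage points lower from compound 3 to compound 4 (within the scatter). Compound 4 is estimated at 74% in this assay, within a range from 60% to 86%.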

Compound 4, a percentage reported as inhibition, at one concentration (the size of the read-out at that concentration, not a potency): 31.3%
Beside the measured number, compound 4's estimate is 42.7 percentage points above it; measured number outside the range, below it.
By their numbers in this assay, from the lowest: compound 4; then compounds 1, 2 and 3 (each within the scatter of the next).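

The earlier steps shown here only moved the ring nitrogen or added a saturated chain carbon, whereas removing that nitrogen has a large effect in this assay: phenyl in place of pyridin-3-yl gives a number 46.7 percentage points lower from compound 3 to compound 4 (beyond the scatter), phenyl in place of pyridin-4-yl gives a number 41.6 percentage points lower from compound 2 to compound 4 (beyond the scatter), and benzyl in place of pyridin-3-yl gives a number 41.2 percentage points lower from compound 1 to compound 4 (beyond the scatter). Among these four compounds, then, the three that carry a pyridine ring stay within the scatter of one another, and only the compound with a carbon-only ring stands apart. Nothing measured here explains this drop.

Still open, on these data alone, is whether another nitrogen-containing ring, such as pyrimidin-5-yl, would keep the higher read-out. As far as these compounds go, it is also open whether an amino or methoxy group on the benzyl ring could restore it.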